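Compound 4: Same Atoms, Joined Differently

This account rests on a few compounds, and the source may have more. Where it says the series, first, only, none or still open, it means among the compounds named here.

In a physicochemical assay for permeability, using PAMPA (on this read-out lower numbers stand for lower permeability and higher numbers for higher permeability), compound 1 `Cc1oc(-c2c(C)c(C)c(C)c(C)c2C)nc1CN1CCC(C(=O)NCCCN2C[C@H](C)C[C@H](C)C2)CC1` gives 455 10^-6 cm/s and compound 3 `CCc1ccccc1-c1nc(CN2CCC(C(=O)NCCCN3C[C@H](C)C[C@H](C)C3)CC2)c(C)o1` gives 106 10^-6 cm/s as the lower of the two numbers available. For compound 2 `Cc1oc(-c2c(Cl)cccc2Cl)nc1CN1CCC(C(=O)NCCCN2C[C@H](C)C[C@H](C)C2)CC1` the result is "not determined" (no result reported), with no number reported. Compound 4 `Cc1ccc(-c2nc(CN3CCC(C(=O)NCCCN4C[C@H](C)C[C@H](C)C4)CC3)c(C)o2)cc1C` carries 3,4-dimethylphenyl in place of 2-ethylphenyl on an aromatic carbon with the same atoms joined differently. Among the compounds with values here, the only measured step at this place, a 4.3-fold lower number from compound 1 to compound 3 (0.63 log units; beyond the scatter) for a different swap, lies beyond the scatter but gives no direction for this one. No step beyond the scatter is therefore expected, and the estimated change is a 1.2-fold higher number from compound 3 to compound 4 (0.09 log units; within the scatter) in size. For compound 4 the expected value is 130 10^-6 cm/s with an estimated range from 45 10^-6 cm/s to 380 10^-6 cm/s for this measurement.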

Compound 4, apparent permeability: 219 10^-6 cm/s
For compound 4 the middle estimate is 1.7-fold (0.23 log units) below the measured one; low and high end bracket the measured number.
By their numbers in this assay, from the lowest: compound 3; then compound 4; then compound 1.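

In this assay, replacing 2-ethylphenyl with 3,4-dimethylphenyl gives a 2.1-fold higher number from compound 3 to compound 4 (0.32 log units; beyond the scatter), so the same atoms joined differently can move this number. Replacing 2,3,4,5,6-pentamethylphenyl with 3,4-dimethylphenyl gives a 2.1-fold lower number from compound 1 to compound 4 (0.32 log units; beyond the scatter), which places the three measured groups at separate levels at this position. Nothing measured here explains these differences.

As far as these compounds go, it remains open whether the ethyl chain or the two methyl groups and their placement matter more, as the two groups differ in both. From the compounds shown here alone, a phenyl ring carrying an amine or a carboxylic acid also remains untested here.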